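Series notes: the step from compound 3 to compound 4

The source may hold more compounds than are shown below. What is called first, only, known or untested is meant among the compounds shown, and "the series" means these compounds.

Measured so far in a functional assay on HepG2 cells (Homo sapiens) for antiproliferative activity, read by MTT assay, with a stated time of 72 h; on this read-out lower numbers stand for stronger inhibition and higher numbers for weaker inhibition:
- compound 1 `O=C1O/C(=C\Cn2cc(-c3cc(F)cc(F)c3)nn2)C(OCc2ccccc2)=C1OCc1ccccc1`: > 100000 nM, a limit of the assay and not a number
- compound 2 `Cc1ccc(-c2cn(C/C=C3\OC(=O)C(OCc4ccccc4)=C3OCc3ccccc3)nn2)cc1`: > 100000 nM, a limit of the assay and not a number
- compound 3 `O=C1O[C@H]([C@@H](O)Cn2cc(CCO)nn2)C(OCc2ccccc2)=C1OCc1ccccc1`: 68100 nM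

Compound 3 is the only one of the three with a number in this assay; the other two values stand at the limit of > 100000 nM in this assay, at which 2 of the 3 values shown sit. Going by the values given here, the single measured step, a step that the two limits leave unreadable from compound 1 to compound 2, runs between two limits and its size cannot be read.

Compound 4 `CCCCCCCCCCc1cn(C[C@H](O)[C@H]2OC(=O)C(OCc3ccccc3)=C2OCc2ccccc2)nn1` differs from compound 3 by octyl in place of hydroxy on a saturated chain carbon, two bonds along the chain from an aromatic carbon. Among the compounds with values here, no measured step touches a saturated chain carbon at this position; the only step on record alters an aromatic substituent and is unreadable, so nothing here supports a step in either direction beyond the scatter in this assay. Compound 4 is therefore estimated at 50000 nM, with a range from 8000 nM to 200000 nM. The expected step is a 1.4-fold lower number from compound 3 to compound 4 (0.13 log units; within the scatter), kept wide for want of bearing evidence.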

Compound 4, half-maximal inhibitory concentration: 12200 nM
Estimate against measurement, compound 4: 4.1-fold (0.61 log units) above; measured number inside the range.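

In this assay, this saturated chain carbon, two bonds along the chain from an aromatic carbon, gives the series its first readable step: octyl in place of hydroxy produces a 5.6-fold lower number from compound 3 to compound 4 (0.75 log units; beyond the scatter). The hydroxy group at this position is therefore not needed for the activity of compound 3, and the position accepts a far larger saturated chain with a modest improvement. The earlier compounds could not show a step of this kind, since compound 1 and compound 2 each stand at a limit of the assay and not a number, and the step between them cannot be read: the limit of > 100000 nM in this assay, at which 2 of the 4 values shown sit.

A single pair cannot separate the loss of the hydroxy group from the arrival of octyl, nor show whether the number follows chain length. A shorter butyl chain, a longer dodecyl chain, or an amine or carboxylic acid at the chain end would leave these questions open here.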